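Swapping the phenyl of compound 1 for an imidazole

The source may report more compounds than this note shows. Statements on the series, on what has been measured and on what is new or still open speak of the compounds shown alone.

Compound 1, `O=C(O)CCc1ccc(NCc2ccccc2)cc1`, is a small carboxylic acid tested in a functional assay for agonist activity at Free fatty acid receptor 1 (Homo sapiens) (a lower number here means that less compound is needed, a higher number that more compound is needed for the effect), where compound 1 gives 7940 nM. Among the two plain numbers in this set, compound 1 sits at the higher end. Its nearest neighbour is compound 2, `COc1ccc(CNc2ccc(CCC(=O)O)cc2)cc1`, which gives 1260 nM in this assay; the step is a 6.3-fold lower number from compound 1 to compound 2 (0.80 log units; beyond the scatter), achieved by placing a methoxy on one aromatic carbon of the benzyl ring. Compound 3, `NC(=O)c1cccc(CNc2ccc(CCC(=O)O)cc2)c1`, carries a carbamoyl on that ring instead and gives only a limit, < 31700 nM, in this assay. Hence a step that the limit leaves unreadable from compound 1 to compound 3, since the limit of < 31700 nM in this assay, at which 1 of the 3 values shown sits, hides the size of that step.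

Compound 4, `O=C(O)CCc1ccc(NCc2ncc[nH]2)cc1`, changes the molecule differently: 1H-imidazol-2-yl in place of phenyl on a saturated chain carbon bound to a nitrogen on an aromatic ring. Neither measured step tests replacing the ring itself; both only decorate it. The step to compound 2 shows this part of the molecule can move the read-out by a modest amount, while compound 3 shows a change there can also push the result past the limit. A change in this assay beyond the scatter is therefore expected, most likely toward a higher number. The estimate for compound 4 is 16000 nM, between 4000 nM and 60000 nM, meaning a 2.0-fold higher number from compound 1 to compound 4 (0.30 log units; within the scatter).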

Compound 4, half-maximal effective concentration: < 31700 nM
Compound 4 ended at the assay's limit; the forecaster's own chance of this, stated with the estimate: 40%; the middle value is on the limit's open side.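

In this assay, among these compounds, compound 4 gives only a limit, < 31700 nM, so no step from compound 1 to compound 4 can be read. The compounds shown leave open how 1H-imidazol-2-yl in place of phenyl truly changes the read-out, and how compound 3 and compound 4 compare with each other: the limit of < 31700 nM in this assay, at which 2 of the 4 values shown sit.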